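The source may hold more compounds than are shown below. What is called first, only, known or untested is meant among the compounds shown, and "the series" means these compounds.

Of the compounds shown here, two built on one shared core have so far been measured in an assay on HEK293 cells for displacement of a labelled ligand from corticotropin-releasing factor receptor 1 (Homo sapiens), read by scintillation counting, with a stated time of 2 h; on this read-out higher numbers stand for weaker inhibition and lower numbers for stronger inhibition. Compound 1 `COCc1cc(OC)c(-c2cccc3c(N(CC4CCOCC4)CC4CC4)c(SC)nn23)c(OC)c1` carries a methylsulfanyl group on an aromatic carbon of the five-membered aromatic ring and gives 35 nM. Compound 2 `COCc1cc(OC)c(-c2cccc3c(N(CC4CCOCC4)CC4CC4)c(C)nn23)c(OC)c1` carries a methyl in that place and gives 120 nM. Going by the values given here, the single step between them, a 3.4-fold higher number from compound 1 to compound 2 (0.54 log units; beyond the scatter), is the exchange of methylsulfanyl for methyl. Among the two numbers compound 2 therefore stands highest, and its nearest neighbour is compound 1.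

Compound 3 `COCc1cc(OC)c(-c2cccc3c(N(CC4CCOCC4)CC4CC4)c(OC)nn23)c(OC)c1` has not yet been measured. Its change from compound 2 is methoxy in place of methyl on an aromatic carbon. Among the compounds with values here, no measured step exchanges methyl for methoxy, so the step from compound 1 to compound 2 bears on it only loosely: it shows that putting methyl in place of methylsulfanyl on this carbon raised the number. Should methoxy sit closer to the methylsulfanyl of compound 1 than to the methyl of compound 2, a lower number than compound 2 is expected, by an amount a 2.0-fold lower number from compound 2 to compound 3 (0.30 log units; within the scatter), though this might also fall within the scatter. Compound 3 is estimated at 60 nM, within a range from 20 nM to 200 nM.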

Compound 3, half-maximal inhibitory concentration in the corticotropin-releasing factor receptor 1 assay: 51 nM
For compound 3 the middle estimate is 1.2-fold (0.07 log units) above the measured one; the measured number falls inside the stated range.
By their numbers in the corticotropin-releasing factor receptor 1 assay, from the lowest: compounds 1 and 3 (each within the scatter of the next); then compound 2.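

In the corticotropin-releasing factor receptor 1 assay the exchange of methyl for methoxy on this aromatic carbon gives a 2.4-fold lower number from compound 2 to compound 3 (0.37 log units; beyond the scatter) and the exchange of methylsulfanyl for methoxy gives a 1.5-fold higher number from compound 1 to compound 3 (0.16 log units; within the scatter) so the lower number of compound 1 is not confined to methylsulfanyl. Methoxy and methylsulfanyl cannot be told apart on this read-out, and among these three groups methyl alone stands apart. Going by these compounds alone, the change also has a second side that the earlier compounds did not show, since in a physicochemical assay for solubility, in phosphate buffer, measured as kinetic solubility (on this read-out higher numbers stand for higher solubility and lower numbers for lower solubility), compound 2 gives 21000 nM and compound 3 gives 5500 nM and so methoxy in place of methyl lowers the solubility number as it lowers the binding number: the measured solubility of compound 2, 21000 nM, and of compound 3, 5500 nM, a 3.8-fold lower number (0.58 log units; beyond the scatter).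

The compounds shown cover only three small groups on this one carbon, and they leave open whether an amine or a longer chain such as ethoxy would keep the lower number in the corticotropin-releasing factor receptor 1 assay while holding the higher number of compound 2 in the physicochemical assay. They also leave open how methylsulfanyl compares with methoxy and methyl on solubility.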